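The compounds below may be only part of what the source reports. "The series", "measured", "known", "first", "only" and "open" are said of these compounds alone.

For the measured compounds named here, compound 1 `COc1cc(N)c(Cl)cc1NC(=O)C1CCN(Cc2cccc(C)c2)CC1` is the only member of this set with a number rather than a limit: in a functional assay on the whole organism for antagonist activity, with Mus musculus as the target (a lower number here means that less compound is needed, a higher number that more compound is needed for the effect), compound 1 gives 2.4 mg/kg. Compound 2 `CCC(CC)CN1CCC(C(=O)Nc2cc(Cl)c(N)cc2OC)CC1` reaches only a limit of the assay, > 10 mg/kg. Compound 3 `COc1cc(N)c(Cl)cc1NC(=O)C1CCN(Cc2ccccc2F)CC1` also ends at a limit, > 4 mg/kg. Both replacements of 3-methylphenyl therefore give a higher number: an at least 4.1-fold higher number from compound 1 to compound 2 (0.61 log units; beyond the scatter), and an at least 1.6-fold higher number from compound 1 to compound 3 (0.22 log units; that floor lies within the scatter). Going by these compounds, the evidence for these steps rests on limits, the limit of > 10 mg/kg in this assay, at which 1 of the 3 values shown sits, and (the limit of > 4 mg/kg in this assay, at which 1 of the 3 values shown sits), so their full size is unknown.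

Compound 4 `COc1cc(N)c(Cl)cc1NC(=O)C1CCN(CC2CCCCC2)CC1` carries the change (cyclohexyl in place of 3-methylphenyl on a saturated chain carbon bound to an amine nitrogen in a ring). Going by the values given here, of the measured steps, the one to compound 2 bears most on it, since pentan-3-yl, like cyclohexyl, is saturated; that step was at least modest, and the step to compound 3 was smaller and within scatter at its floor. A higher number is therefore expected in this assay, with the estimated step of a 2.5-fold higher number from compound 1 to compound 4 (0.40 log units; beyond the scatter). For compound 4 the estimated value is 6 mg/kg, with a range from 2.4 mg/kg to 15 mg/kg.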

Compound 4, dose for half-maximal effect: 2.9 mg/kg
For compound 4 the middle estimate is 2.1-fold (0.32 log units) above the measured one, within the range that was stated.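

In this assay, the non-aromatic cyclohexyl cannot be told apart from the aromatic 3-methylphenyl at this position: a 1.2-fold higher number from compound 1 to compound 4 (0.08 log units; within the scatter). Compound 2 stands at a limit of the assay, and its open-chain pentan-3-yl separates from cyclohexyl in an at least 3.4-fold lower number from compound 2 to compound 4 (0.53 log units; beyond the scatter), so among the compounds shown the absence of an aromatic ring does not by itself give the higher number, and the size of this step stays unknown: the limit of > 10 mg/kg in this assay, at which 1 of the 4 values shown sits. Compound 3 also stands at a limit of the assay, and an at least 1.3-fold lower number from compound 3 to compound 4 (0.13 log units; that floor lies within the scatter) does not separate 2-fluorophenyl from cyclohexyl: the limit of > 4 mg/kg in this assay, at which 1 of the 4 values shown sits.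

Open, going by these compounds, is whether a cyclopentyl ring on the same saturated chain carbon reads like cyclohexyl. Also open, on these data alone, is whether cyclohexyl carrying a hydroxyl or an amine keeps the value of compound 4.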